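Para-substituent scan on the aryl group of the series

A few compounds are considered here, and "the series" means these few. Any claim that something is new, unique, unknown or untested is made for them only; others in the source may bear on it.

Measured in a functional assay on MOLT-4 cells (Homo sapiens) for cytotoxicity, read by CCK-8 assay, with a stated time of 24 h; on this read-out higher numbers stand for weaker inhibition and lower numbers for stronger inhibition:
compound 1 `C=CC(=O)N1C(=O)CC(c2ccc(OC)cc2)Sc2ccccc21` gives 83200 nM
compound 2 `C=CC(=O)N1C(=O)CC(c2ccc([N+](=O)[O-])cc2)Sc2ccccc21` gives 91500 nM

Among the measured compounds shown here, compound 2, at 91500 nM, lies within the scatter of compound 1, the only other compound measured so far, so neither can be ranked above the other. The next comparison is compound 3 `C=CC(=O)N1C(=O)CC(c2ccccc2)Sc2ccccc21`, which differs from compound 2 as follows: hydrogen in place of nitro on an aromatic carbon. In words, this is hydrogen in place of nitro on an aromatic carbon, para to a large group.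

For the measured compounds named here, one measured step bears on this change: a 1.1-fold higher number from compound 1 to compound 2 (0.04 log units; within the scatter). That step, nitro in place of methoxy on an aromatic carbon, stays within the scatter. Going by the values given here, the evidence is thin, since it is a single step and no measured compound carries hydrogen at this place. Even so, exchanging these two groups left the number in this assay essentially unmoved, so no step beyond the scatter is expected, and no direction can be assigned. The estimated step is a 1.1-fold lower number from compound 2 to compound 3 (0.03 log units; within the scatter). For compound 3 the expected value is 85000 nM, with an estimated range of 50000 nM to 145000 nM.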

Compound 3, half-maximal inhibitory concentration: 85900 nM
The estimate for compound 3 lay 1.0-fold (0.00 log units) below the measured number, within the range that was stated.
By their numbers in this assay, from the lowest: compounds 1, 3 and 2 (each within the scatter of the next).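

In this assay, hydrogen in place of nitro on an aromatic carbon, para to a large group, gives a 1.1-fold lower number from compound 2 to compound 3 (0.03 log units; within the scatter), and hydrogen in place of methoxy at the same place gives a 1.0-fold higher number from compound 1 to compound 3 (0.01 log units; within the scatter). With hydrogen now measured at this place, both substituents can be read against the compound that carries neither, and neither step leaves the scatter, so compounds 1, 2 and 3 cannot be separated in this assay and this position shows no dependence on which of these three groups it carries. No measured property of these groups or compounds accompanies these numbers, so nothing here accounts for the lack of separation.

Still open, as far as these compounds go, is whether any other group at this place, such as an amine, a carboxylic acid, a halogen or a longer alkyl chain, would produce a step beyond the scatter. Also open, from the compounds shown here alone, is whether changes elsewhere on the shared core would move the number in this assay when this place, as in these three compounds, contributes no readable difference.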